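Compound 3 to compound 4: replacing the 4-nitrophenyl group

The source may hold more compounds than are shown below. What is called first, only, known or untested is meant among the compounds shown, and "the series" means these compounds.

Among the measured compounds shown here, in a functional assay on MCF7 cells (Homo sapiens) for cytotoxicity, read by MTT assay, with a stated time of 96 h (a higher number here means a weaker inhibitor, a lower number a stronger inhibitor), compound 3 `COc1cc(C(=O)c2cn(-c3ccccc3)cc2-c2ccc([N+](=O)[O-])cc2)cc(OC)c1OC` gives 590 nM and stands highest of the three numbers so far. In this assay compound 1 `COc1cc(C(=O)c2cn(-c3ccccc3)cc2-c2ccccc2C)cc(OC)c1OC` gives 190 nM and compound 2 `COc1cc(C(=O)c2cn(-c3ccccc3)cc2-c2ccc(Cl)cc2)cc(OC)c1OC` gives 290 nM as its value. Compound 4 `COc1cc(C(=O)c2cn(-c3ccccc3)cc2-c2c(F)cc(F)cc2F)cc(OC)c1OC` differs from compound 3 by one change 2,4,6-trifluorophenyl in place of 4-nitrophenyl on an aromatic carbon with 2,4,6-trifluorophenyl in place of 4-nitrophenyl on an aromatic carbon.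

Three measured steps at this same place bear on it. The series shows a 3.1-fold higher number from compound 1 to compound 3 (0.49 log units; beyond the scatter) and a 2.0-fold higher number from compound 2 to compound 3 (0.31 log units; beyond the scatter) as modest steps, whereas a 1.5-fold higher number from compound 1 to compound 2 (0.18 log units; within the scatter) stays small. Both compounds without 4-nitrophenyl therefore read lower than compound 3, but neither carries 2,4,6-trifluorophenyl, so the evidence is indirect. A modest step towards a lower number is expected, of about the size of those two steps. The estimated change is a 2.4-fold lower number from compound 3 to compound 4 (0.37 log units; beyond the scatter) in this assay as a working figure. For compound 4 the estimate is 250 nM with an expected range from 80 nM to 800 nM as its upper end.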

Compound 4, half-maximal inhibitory concentration: 180 nM
The estimate for compound 4 lay 1.4-fold (0.14 log units) above the measured number; measured number inside the range.
By their numbers in this assay, from the lowest: compounds 4, 1 and 2 (each within the scatter of the next); then compound 3.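

In this assay, the change to 2,4,6-trifluorophenyl gives a 3.3-fold lower number from compound 3 to compound 4 (0.52 log units; beyond the scatter), so compound 3 now stands apart from all three other rings at this position, not only from those of compound 1 and compound 2. The new ring cannot be told apart from the other two: a 1.6-fold lower number from compound 2 to compound 4 (0.21 log units; within the scatter) and a 1.1-fold lower number from compound 1 to compound 4 (0.02 log units; within the scatter) both stay within the scatter, so a ring carrying three fluorine atoms reads alike with the 4-chlorophenyl and 2-methylphenyl rings here. No evidence on hand accounts for these readings.

The compounds shown all carry a substituted phenyl ring at this position, so it stays open whether a ring bearing an amine or a carboxylic acid would read with compound 3 or with the other three. On these data alone, whether the same pattern holds with another group in place of the phenyl group also stays open.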